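From 4-nitrophenyl to 1H-indol-7-yl on a shared core

The source may report more compounds than this note shows. Statements on the series, on what has been measured and on what is new or still open speak of the compounds shown alone.

Compound 1 `COc1ccc(-c2cccc(=O)n2-c2cc(OC)c(OC)c(OC)c2)cc1OCc1ccccc1`: 269 nM
Compound 2 `COc1ccc(-c2cccc(=O)n2-c2cc(OC)c(OC)c(OC)c2)cc1OC`: 513 nM
Compound 3 `COc1cc(-n2c(-c3ccc([N+](=O)[O-])cc3)cccc2=O)cc(OC)c1OC`: < 10 nM (a limit, not a number)

All three results come from a functional assay on HepG2 cells (Homo sapiens) for cytotoxicity, read by spectrophotometry, with a stated time of 72 h; on this read-out lower numbers stand for stronger inhibition and higher numbers for weaker inhibition. Compound 3 is reported only as a limit: the limit of < 10 nM in this assay, at which 1 of the 3 values shown sits.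

Compound 4 `COc1cc(-n2c(-c3cccc4cc[nH]c34)cccc2=O)cc(OC)c1OC` keeps the shared core but carries 1H-indol-7-yl in place of 4-nitrophenyl (1H-indol-7-yl in place of 4-nitrophenyl on an aromatic carbon). Among the compounds with values here, no measured step covers this swap. The one available, a 1.9-fold higher number from compound 1 to compound 2 (0.28 log units; within the scatter), lies elsewhere on the molecule and stays within the scatter. The best guide is that compound 1, at 269 nM, and compound 2, at 513 nM, also lack 4-nitrophenyl. A move toward weaker inhibition is therefore expected, with an estimated size of an at least 6.0-fold higher number from compound 3 to compound 4 (0.77 log units; beyond the scatter) in this assay. The estimate for compound 4 is 60 nM, with an expected range from 10 nM to 400 nM.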

Compound 4, half-maximal inhibitory concentration: 2400 nM
For compound 4 the middle estimate is 40-fold (1.60 log units) below the measured one; measured number above the stated range.
By their numbers in this assay, from the lowest: compounds 1 and 2 (each within the scatter of the next); then compound 4. At a limit, below all of these: compound 3.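

At this aromatic carbon next to the ring nitrogen, the choice of group matters greatly in this assay: an at least 240-fold higher number from compound 3 to compound 4 (2.38 log units; beyond the scatter). Within the data shown here, the only earlier step lay elsewhere on the molecule and stayed within the scatter, so this is the first clear sign that the numbers on this core can shift strongly with a single change. The figure for compound 3 is a limit, not a number: the limit of < 10 nM in this assay, at which 1 of the 4 values shown sits.

With only 4-nitrophenyl and 1H-indol-7-yl shown at this carbon, it remains open how much of the gap belongs to the nitro group and how much to the ring bearing it. A plain phenyl, or a phenyl carrying an amine in place of the nitro group, could help separate the two.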